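A few compounds are considered here, and "the series" means these few. Any claim that something is new, unique, unknown or untested is made for them only; others in the source may bear on it.

Of the compounds shown here, three have been measured in a functional assay on the whole organism with Scenedesmus acutus as the target, read by spectrophotometry; on this read-out lower numbers stand for stronger inhibition and higher numbers for weaker inhibition. Compound 1 `Cc1cc(Cl)ccc1/N=c1\sc(=S)n2n1CCCC2` gives 275 nM, compound 2 `Fc1cc(Cl)ccc1-n1c(=S)n2n(c1=S)CCCC2` gives 18.2 nM, and compound 3 `CC(C)Oc1cc(/N=c2\sc(=S)n3n2CCCC3)c(F)cc1Cl` gives 11.2 nM. Compound 3 and compound 2 lie within the scatter of each other at the low end of these numbers, while the gap from compound 3 up to compound 1 lies beyond the scatter.

Compound 4 `Fc1cc(Cl)ccc1/N=c1\sc(=S)n2n1CCCC2`, not yet measured, keeps the core of compound 3 and has hydrogen in place of isopropoxy on an aromatic carbon.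

Among the compounds with values here, no measured pair differs in one place alone, so this step has no direct precedent in this assay, and only indirect hints are available. With the core of compound 3 but a methyl group in place of the fluoro group and no isopropoxy group, compound 1 gives 275 nM. On a different core, with the chloro and fluoro groups of compound 4 and no isopropoxy group, compound 2 gives 18.2 nM. These two values pull in different directions, so a moderate rise toward weaker inhibition is expected, probably beyond the scatter.

The estimated change, a 5.4-fold higher number from compound 3 to compound 4 (0.73 log units; beyond the scatter), is correspondingly uncertain. For compound 4 the expected value is 60 nM, with an estimated range of 18 nM to 200 nM.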

Compound 4, half-maximal inhibitory concentration: 67.6 nM
The estimate for compound 4 lay 1.1-fold (0.05 log units) below the measured number; the measured number falls inside the stated range.
By their numbers in this assay, from the lowest: compounds 3 and 2 (each within the scatter of the next); then compound 4; then compound 1.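

Hydrogen in place of isopropoxy on an aromatic carbon, ortho to a chloro group and para to a fluoro group, gives a 6.0-fold higher number from compound 3 to compound 4 (0.78 log units; beyond the scatter) in this assay and is the first one-place reading at this position: on this core, with the chloro and fluoro groups kept, the isopropoxy group goes with the lower number, by a step printed as modest but beyond the scatter. Within the data shown here, compound 4 also gives the first one-place reading of fluoro in place of methyl on an aromatic carbon, with a 4.1-fold lower number from compound 1 to compound 4 (0.61 log units; beyond the scatter), so the large gap between compound 1 and compound 3 now resolves into two separate modest steps, one for each changed group. No measurement in hand accounts for either step.

Going by these compounds, whether methoxy, a longer alkoxy chain, an amine or a carboxylic acid at the isopropoxy position would match, exceed or fall short of compound 3 remains open. Also open, on these data alone, is whether isopropoxy has a similar effect on the core of compound 2, or with methyl in place of fluoro on the shared core.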